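Methyl removal on the aryl amide, cytotoxicity in THP-1 cells

The source may hold more compounds than are shown below. What is called first, only, known or untested is meant among the compounds shown, and "the series" means these compounds.

Measured compounds:
compound 1 `Cn1c(-c2ccccc2)cnc1NC(=O)c1ccc(F)cc1` — in a toxicity assay on THP-1 cells (Homo sapiens) for inhibition (a higher number here means that more compound is tolerated, a lower number that less compound is tolerated), compound 1 gives > 100000 nM, which is a limit of the assay.
compound 2 `Cc1cccc(C(=O)Nc2ncc(-c3ccccc3)n2C)c1` — in this assay compound 2 gives > 50000 nM, also a limit of the assay.
compound 3 `Cc1ccccc1-c1cnc(NC(=O)c2ccc(F)cc2)n1C` — in this assay compound 3 gives > 50000 nM, again a limit of the assay.

All three values are limits, so no number is known for any of them. The step that the two limits leave unreadable from compound 3 to compound 1 is the change (hydrogen in place of methyl on an aromatic carbon); its size cannot be read, since the limit of > 50000 nM in this assay, at which 2 of the 3 values shown sit, and the limit of > 100000 nM in this assay, at which 1 of the 3 values shown sits, are the bounds involved. Likewise a step that the two limits leave unreadable from compound 1 to compound 2 stays unreadable between the two limits. The difference between the cores of compound 2 and compound 3 is not broken down here.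

Compound 4 `Cn1c(-c2ccccc2)cnc1NC(=O)c1ccccc1` is not yet measured. It arises from compound 2 by hydrogen in place of methyl on an aromatic carbon, the same kind of change as from compound 3 to compound 1, though there the methyl sat ortho to a large group and here it sits meta to a large group. Since compound 2 gives > 50000 nM as a limit and compound 1, the closest analogue, gives > 100000 nM as a limit, compound 4 is expected to show a step that the limit leaves unreadable from compound 2 to compound 4, most likely again only as a limit. The expected value for compound 4 in this assay is 100000 nM.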

Compound 4, half-maximal cytotoxic concentration: > 100000 nM
Compound 4 gave a limit, no number; the forecaster's own chance of this, stated with the estimate: 90%; the middle value lies on the limit itself.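

In this assay compound 4 gives > 100000 nM, which is a limit of the assay. Among the compounds shown here, compound 1 and compound 2 also stand only as limits, so no step from either of them to compound 4 can be read. The compounds shown leave open whether hydrogen, methyl or fluoro on the aromatic ring of the amide makes any difference in this assay.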